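Propyl on the Amine: a Step from Compound 1

This account rests on a few compounds, and the source may have more. Where it says the series, first, only, none or still open, it means among the compounds named here.

Three compounds have numbers in a functional assay on the whole organism with Canis familiaris (Canis lupus familiaris) as the target, at a dose of 2 mg/kg by the intravenous route; a lower number here means a weaker effect, a higher number a stronger effect of the compound at the dose given:
compound 1 `Cc1nc2c(OCc3ccccc3)cccn2c1N` with 97%;
compound 2 `Cc1nc2c(OCc3ccsc3)cccn2c1N` with 82%;
compound 3 `Cc1cc(OCc2ccccc2)c2nc(C)c(N)n2c1` with 46%.

Compound 1 stands highest of the three, and each of the other two lies beyond the scatter below it. Both differ from compound 1 in one place. Compound 2 carries thiophen-3-yl in place of phenyl on a saturated chain carbon bound to an oxygen on an aromatic ring, and this gave a number 15 percentage points lower from compound 1 to compound 2 (beyond the scatter). Compound 3 carries methyl in place of hydrogen on an aromatic carbon, and this gave a number 51 percentage points lower from compound 1 to compound 3 (beyond the scatter).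

Compound 4 `CCCNc1c(C)nc2c(OCc3ccccc3)cccn12` has not yet been measured. It differs from compound 1 as follows: propyl in place of hydrogen on a nitrogen on an aromatic ring. Among the compounds with values here, neither measured step touches the nitrogen on the aromatic ring, so no step bears directly on this change. What the two measured steps share is their direction: both changes from compound 1 lowered the number, once modestly and once by a large amount, and compound 1 already stands near the top of the scale. The expectation for compound 4 is therefore a drop rather than a rise, of a size that these data cannot fix closely. Compound 4 is estimated at 78%, within 45% to 98%, which means an expected a number 19 percentage points lower from compound 1 to compound 4 (beyond the scatter).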

Compound 4, a percentage reported as inhibition, in the whole organism at one dose (the size of the read-out at that dose, not a potency): 12%
For compound 4 the middle estimate is 66 percentage points above the measured one; the measured number lies below the stated range.
By their numbers in this assay, from the lowest: compound 4; then compound 3; then compound 2; then compound 1.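

Propyl on the nitrogen is the first change shown at this position, and in this assay going from amino to propylamino gave a number 85 percentage points lower from compound 1 to compound 4 (beyond the scatter). This is the largest step from compound 1 among those shown, larger than the change on the aromatic carbon, which gave a number 51 percentage points lower from compound 1 to compound 3 (beyond the scatter), so the amino nitrogen proves far less forgiving of change than the two places varied before, and the propyl group leaves little of the effect at this dose. No measurement shown here offers an explanation for this loss.

The compounds shown leave open whether the loss belongs to propyl in particular or to any group on this nitrogen, and an ethyl group, an acetyl group or a longer chain such as butyl in the same place would tell these cases apart. They also leave open how compound 4 would behave at other doses, as a single dose gives the size of the read-out at that dose and not a potency.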